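The source may hold more compounds than are shown below. What is called first, only, known or untested is meant among the compounds shown, and "the series" means these compounds.

Measured compounds:
- compound 1 `Cc1cc(S(=O)(=O)/N=C(\N)n2nccc2-c2ccccc2)c(SCc2ccccc2Cl)cc1Cl`: 0.226 h
- compound 2 `Cc1cc(-c2ccccc2)n(/C(N)=N/S(=O)(=O)c2cc(C)c(Cl)cc2SCc2ccc(C(F)(F)F)cc2)n1`: 0.241 h
- compound 3 `Cc1cc(-c2ccccc2)n(/C(N)=N/S(=O)(=O)c2cc(C)c(Cl)cc2SCc2ccccc2Cl)n1`: 0.163 h

In an ADME assay on microsomes from liver (Homo sapiens) for metabolic stability, read by LC-MS, using NADPH, tested at 5 uM (on this read-out lower numbers stand for a shorter-lived compound and higher numbers for a longer-lived compound), compound 3 gives 0.163 h. This is the smallest of the three numbers, but the steps of a 1.4-fold lower number from compound 1 to compound 3 (0.14 log units; within the scatter) and a 1.5-fold lower number from compound 2 to compound 3 (0.17 log units; within the scatter) both lie within the scatter, so the three compounds cannot be told apart on this read-out; each is cleared quickly.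

Compound 4 `Cc1ccc(CSc2cc(Cl)c(C)cc2S(=O)(=O)/N=C(\N)n2nc(C)cc2-c2ccccc2)cc1` is not yet measured. It differs from compound 3 in one place: 4-methylphenyl in place of 2-chlorophenyl on a saturated chain carbon bound to a sulfur. Among the compounds with values here, of the measured steps, only the one from compound 2 to compound 3 touches the same position, the saturated chain carbon bound to a sulfur, and it was a 1.5-fold lower number from compound 2 to compound 3 (0.17 log units; within the scatter), within the scatter. The step from compound 1 to compound 3, a 1.4-fold lower number from compound 1 to compound 3 (0.14 log units; within the scatter), changes a different part of the molecule and says nothing direct about this swap. Within the data shown here, with one small step as the only guide, no step beyond the scatter is expected in this assay for compound 4, with at most a slight drift toward a higher number as seen for compound 2.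

Compound 4 is therefore expected to give about 0.2 h in this assay, with a range from 0.1 h to 0.4 h. The estimated step is a 1.2-fold higher number from compound 3 to compound 4 (0.09 log units; within the scatter).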

Compound 4, half-life: 0.176 h
Compound 4: the middle estimate sits 1.1-fold (0.06 log units) above what was measured; measured number inside the range.
By their numbers in this assay, from the lowest: compounds 3, 4, 1 and 2 (each within the scatter of the next).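

In this assay, the swap of 2-chlorophenyl for 4-methylphenyl on a saturated chain carbon bound to a sulfur gives a 1.1-fold higher number from compound 3 to compound 4 (0.03 log units; within the scatter), and the swap of trifluoromethyl for methyl on an aromatic carbon gives a 1.4-fold lower number from compound 2 to compound 4 (0.14 log units; within the scatter). Before this result, only a single swap of this group could be read; now 2-chlorophenyl, 4-(trifluoromethyl)phenyl and 4-methylphenyl can all be compared on the same background, and no pair among compound 2, compound 3 and compound 4 separates beyond the scatter, so in these three compounds neither the kind of group on the phenyl ring nor where the name places it sets the half-life apart. Nothing at hand shows which part of these molecules is broken down in the microsomes, or why the half-lives of these compounds stay so alike.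

The compounds shown all carry a plain hydrocarbon, halogen or fluorinated group on this phenyl ring, so they leave open whether an amine or a carboxylic acid there would give a step beyond the scatter. They also leave open whether a longer chain between the sulfur and the phenyl ring would change the half-life.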